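A few compounds are considered here, and "the series" means these few. Any claim that something is new, unique, unknown or untested is made for them only; others in the source may bear on it.

In a functional assay on HL-60 cells (Homo sapiens) for cytotoxicity, read by WST assay, with a stated time of 48 h (a lower number here means that less compound is needed, a higher number that more compound is needed for the effect), compound 1 (`O=C1OC[C@H](Cc2ccccc2)[C@H]1Cc1ccc(Cl)c(Cl)c1`) gives 19000 nM and compound 2 (`O=C1OC[C@H](Cc2ccccc2O)[C@H]1Cc1ccc(Cl)c(Cl)c1`) gives 33000 nM while compound 3 (`Cc1cccc(C[C@H]2COC(=O)[C@@H]2Cc2ccc(Cl)c(Cl)c2)c1`) gives 22000 nM on the same read-out. Compound 3 stands clear of neither of the others, with a 1.2-fold higher number from compound 1 to compound 3 (0.06 log units; within the scatter) and a 1.5-fold lower number from compound 2 to compound 3 (0.18 log units; within the scatter) as the steps that reach it.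

Compound 4 (`Cc1ccc(C[C@H]2COC(=O)[C@@H]2Cc2ccc(Cl)c(Cl)c2)cc1C`) differs from compound 3 by one change (methyl in place of hydrogen on an aromatic carbon) with methyl in place of hydrogen on an aromatic carbon, ortho to a methyl group and para to a large group, so 3-methylphenyl becomes 3,4-dimethylphenyl.

Among the measured compounds shown here, the closest precedent is the same replacement, seen as a 1.2-fold higher number from compound 1 to compound 3 (0.06 log units; within the scatter) in that pair, and the hydroxy replacement gave a 1.7-fold higher number from compound 1 to compound 2 (0.24 log units; within the scatter) as its step. Neither left the scatter, so no step beyond the scatter is expected in this assay for the added methyl, and the estimated move is a 1.1-fold lower number from compound 3 to compound 4 (0.04 log units; within the scatter) on these grounds. Compound 4 is expected at 20000 nM with an estimated range from 10000 nM to 38000 nM in this series.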

Compound 4, half-maximal effective concentration: 16000 nM
Beside the measured number, compound 4's estimate is 1.3-fold (0.10 log units) above it; the measured number falls inside the stated range.
By their numbers in this assay, from the lowest: compounds 4, 1, 3 and 2 (each within the scatter of the next, the first and the last beyond it).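

In this assay, a methyl on an aromatic carbon, ortho to a methyl group and para to a large group, leaves the number within the scatter, with a 1.4-fold lower number from compound 3 to compound 4 (0.14 log units; within the scatter). The full change from phenyl to 3,4-dimethylphenyl also stays within it, with a 1.2-fold lower number from compound 1 to compound 4 (0.07 log units; within the scatter), so this position takes the added methyl without a readable change. Among the compounds shown here, replacing 2-hydroxyphenyl with 3,4-dimethylphenyl gives the only step beyond the scatter, a modest one, with a 2.1-fold lower number from compound 2 to compound 4 (0.31 log units; beyond the scatter); nothing available accounts for this step.

From the compounds shown here alone, whether a carboxylic acid or an amine at this same place would move the number beyond the scatter stays open. So does whether a longer chain such as propyl in place of the added methyl would leave the number unchanged.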